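Swapping 2-aminophenyl for 3-bromophenyl on a shared core

The compounds below may be only part of what the source reports. "The series", "measured", "known", "first", "only" and "open" are said of these compounds alone.

In a functional assay on MCF7 cells (Homo sapiens) for cytotoxicity, read by MTT assay, with a stated time of 96 h (on this read-out lower numbers stand for stronger inhibition and higher numbers for weaker inhibition), compound 1 (`COc1cc(C(=O)c2cn(-c3ccccc3)cc2-c2ccc(N)cc2)cc(OC)c1OC`) gives 9 nM, compound 2 (`COc1cc(C(=O)c2cn(-c3ccccc3[N+](=O)[O-])cc2-c2ccccc2)cc(OC)c1OC`) gives 5000 nM and compound 3 (`COc1cc(C(=O)c2cn(-c3ccccc3N)cc2-c2ccccc2)cc(OC)c1OC`) gives 3800 nM. Compound 3 therefore stands level with compound 2, within the scatter, and far above compound 1.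

The next structure is compound 4 (`COc1cc(C(=O)c2cn(-c3cccc(Br)c3)cc2-c2ccccc2)cc(OC)c1OC`), and the change is 3-bromophenyl in place of 2-aminophenyl on an aromatic nitrogen. In words, 3-bromophenyl comes in place of 2-aminophenyl on an aromatic nitrogen.

For the measured compounds named here, only one measured step bears directly on this group: a 1.3-fold lower number from compound 2 to compound 3 (0.12 log units; within the scatter), with amino in place of nitro on an aromatic carbon. Going by the values given here, that step stays within the scatter, but it says little about replacing the whole group, and no measured compound carries bromine. Compound 1, at 9 nM, shows that low numbers are reachable on this core. However, it differs from compound 3 in more than one place, so its gap cannot be carried over whole. A moderate move towards a lower number is therefore expected, with wide uncertainty.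

The estimated change is a 9.5-fold lower number from compound 3 to compound 4 (0.98 log units; beyond the scatter). For compound 4 the expected value is 400 nM, with an estimated range from 50 nM to 3000 nM.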

Compound 4, half-maximal inhibitory concentration: 78 nM
Estimate against measurement, compound 4: 5.1-fold (0.71 log units) above, within the range that was stated.
By their numbers in this assay, from the lowest: compound 1; then compound 4; then compounds 3 and 2 (each within the scatter of the next).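

On an aromatic nitrogen of the shared core, the group carried there can shift the number a long way: in this assay, 3-bromophenyl in place of 2-aminophenyl gives a 49-fold lower number from compound 3 to compound 4 (1.69 log units; beyond the scatter) on this core, and 3-bromophenyl in place of 2-nitrophenyl gives a 64-fold lower number from compound 2 to compound 4 (1.81 log units; beyond the scatter) with the rest of the structure unchanged. For the compounds shown here, until now the only step touching this group, a 1.3-fold lower number from compound 2 to compound 3 (0.12 log units; within the scatter), stayed within the scatter, and it could have suggested that this position matters little; the two new steps, both large and beyond the scatter, show that it does matter, even though the entering and leaving groups each have 7 heavy atoms and one six-membered aromatic ring of carbon only. Nothing available on these compounds accounts for the size of these steps.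

Each new step changes both the atom on the phenyl ring and its place, so the compounds shown cannot separate the contribution of bromine from that of its place on the ring. A 2-bromophenyl or a 3-aminophenyl group on the same nitrogen would divide the two, and a 3-chlorophenyl or 3-methoxyphenyl group would show whether bromine itself is needed there.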